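Series notes: trifluoromethyl to hydroxymethyl on compound 3

A few compounds are considered here, and "the series" means these few. Any claim that something is new, unique, unknown or untested is made for them only; others in the source may bear on it.

For the measured compounds named here, compound 1 `Clc1ccc(Nc2nccs2)cc1OCC1=CCCC1` gives 15000 nM in a functional assay on MT2 cells (Homo sapiens) for cytotoxicity, read by MTT assay (a higher number here means that more compound is tolerated, a lower number that less compound is tolerated), and compound 2 `CC1=C(COc2cc(Nc3nccs3)ccc2Cl)CCC1` gives 11000 nM; the single step between them, a 1.4-fold lower number from compound 1 to compound 2 (0.13 log units; within the scatter), stays within the scatter. Compound 3 `CC(C)=CCOc1cc(Nc2nccc(C(F)(F)F)n2)ccc1Cl` gives 2500 nM, the lowest of the three numbers: compound 2 stands higher by a margin beyond the scatter, and compound 1 higher still. Compound 4 `CC(C)=CCOc1cc(Nc2nccc(CO)n2)ccc1Cl` differs from compound 3 in one place: hydroxymethyl in place of trifluoromethyl on an aromatic carbon. Going by the values given here, no measured step exchanges these groups or touches this ring; the one step at hand concerns a methyl elsewhere on the shared core and was within the scatter. No direction is therefore supported, and compound 4 is estimated at 3500 nM, with a range of 1200 nM to 12000 nM. The implied step, a 1.4-fold higher number from compound 3 to compound 4 (0.15 log units; within the scatter), is expected to remain within the scatter.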

Compound 4, half-maximal cytotoxic concentration: 220 nM
For compound 4 the middle estimate is 16-fold (1.20 log units) above the measured one; measured number outside the range, below it.
By their numbers in this assay, from the lowest: compound 4; then compound 3; then compounds 2 and 1 (each within the scatter of the next).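

In this assay, hydroxymethyl in place of trifluoromethyl on this aromatic carbon, next to the ring nitrogen, gives an 11-fold lower number from compound 3 to compound 4 (1.06 log units; beyond the scatter). For the compounds shown here, the position is therefore sensitive to substitution in this assay, whereas the only earlier step, a methyl change elsewhere on the shared core, stayed within the scatter. Nothing on hand bears on why this exchange has so large an effect.

As far as these compounds go, whether the step follows from losing trifluoromethyl or from gaining hydroxymethyl remains open; a plain methyl, a methoxymethyl or an aminomethyl group at this carbon would help separate the two. From the compounds shown here alone, whether the step carries over to other side chains on the shared core also remains open.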